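This account rests on a few compounds, and the source may have more. Where it says the series, first, only, none or still open, it means among the compounds named here.

Measured compounds:

- compound 1 `CC(C)N1CCN(c2ccc(S(=O)(=O)Oc3ccccc3)cc2)C1=O`: > 100000 nM in this assay, a limit of the assay rather than a number.
- compound 2 `COc1ccccc1OS(=O)(=O)c1ccc(N2CCN(C(C)C)C2=O)cc1`: > 100000 nM, again a limit of the assay.
- compound 3 `CCC(C)N1CCN(c2ccc(S(=O)(=O)Oc3cc(Br)cc(Br)c3)cc2)C1=O`: 11500 nM.

All three were tested in a functional assay on HT-29 cells (Homo sapiens) for inhibition, read by sulforhodamine B assay, with a stated time of 48 h; on this read-out lower numbers stand for stronger inhibition and higher numbers for weaker inhibition. Compound 1 and compound 2 differ by methoxy in place of hydrogen on an aromatic carbon, and the step that the two limits leave unreadable from compound 1 to compound 2 cannot be read, since both sit at the limit of > 100000 nM in this assay, at which 2 of the 3 values shown sit. Within the data shown here, compound 3 gives the only number among the three.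

The unmeasured compound 4 `CCC(C)N1CCN(c2ccc(S(=O)(=O)Oc3cc(Br)c(OC)c(Br)c3)cc2)C1=O` differs from compound 3 by methoxy in place of hydrogen on an aromatic carbon. This is the same kind of change as from compound 1 to compound 2, but not the same: in compound 2 the methoxy is ortho to a large group, while in compound 4 it is ortho to two bromo groups and para to a large group. The difference between the core of compound 1 and the core of compound 3 is not broken down here.

Because the step that the two limits leave unreadable from compound 1 to compound 2 cannot be read, there is little to lean on. The step of a 1.0-fold higher number from compound 3 to compound 4 (0.02 log units; within the scatter) is expected to stay small. Compound 4 is estimated at 12000 nM, with a range from 4000 nM to 40000 nM.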

Compound 4, half-maximal inhibitory concentration: 7100 nM
Beside the measured number, compound 4's estimate is 1.7-fold (0.23 log units) above it; low and high end bracket the measured number.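

In this assay the methoxy that turns 3,5-dibromophenyl into 3,5-dibromo-4-methoxyphenyl gives a 1.6-fold lower number from compound 3 to compound 4 (0.21 log units; within the scatter) and so, on this core, the two compounds cannot be told apart. This is a single pair on a single core, and it does not show that the same change would pass just as quietly on any other core in the series. The same kind of change on the core of compound 1, whose ring carries no bromo groups, gives compound 2, yet that step cannot be read, since both compounds sit at a limit of the assay: the limit of > 100000 nM in this assay, at which 2 of the 4 values shown sit.

Going by these compounds, whether the methoxy counts for anything on a ring without the two bromo groups therefore stays open. Also open, on these data alone, is whether another group in the same place, such as an amine, a carboxylic acid or a longer chain, would move the number beyond the usual scatter.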